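Swapping the benzyltriazole arm for cyclopentyl on a Ret inhibitor

The compounds below may be only part of what the source reports. "The series", "measured", "known", "first", "only" and "open" are said of these compounds alone.

The measured compounds:
compound 1 `CNc1ncc2c(-c3ccc(N4CCNCC4)nc3)nn(CC3CCCC3)c2n1`, 50 nM
compound 2 `CNc1ncc2c(-c3ccc(N4CCN(C)CC4)nc3)nn(Cc3cn(Cc4ccccc4)nn3)c2n1`, 900 nM
compound 3 `CNc1ncc2c(-c3ccc(N4CCN(C(=O)C(C)(C)C)CC4)nc3)nn(Cc3cn(Cc4ccccc4)nn3)c2n1`, 4000 nM

In an assay for inhibition of proto-oncogene tyrosine-protein kinase receptor Ret (Homo sapiens), read by 33P incorporation, in the presence of a further agent that is not named here (on this read-out higher numbers stand for weaker inhibition and lower numbers for stronger inhibition), compound 2 stands second highest of the three numbers; compound 3 gives a number higher by a 4.4-fold higher number from compound 2 to compound 3 (0.65 log units; beyond the scatter), while compound 1 gives 50 nM. Compound 4 `CNc1ncc2c(-c3ccc(N4CCN(C)CC4)nc3)nn(CC3CCCC3)c2n1` differs from compound 2 by cyclopentyl in place of 1-benzyl-1H-1,2,3-triazol-4-yl on a saturated chain carbon bound to an aromatic nitrogen. For the measured compounds named here, no measured step covers exactly this change. Compound 1, which carries the same cyclopentyl group but hydrogen in place of methyl on an amine nitrogen in a ring, shows a much lower number than compound 2, and the step of a 4.4-fold higher number from compound 2 to compound 3 (0.65 log units; beyond the scatter) shows that the substituent on that amine nitrogen also moves the read-out. Compound 4 is therefore expected to land between those two, with a step of an 8.2-fold lower number from compound 2 to compound 4 (0.91 log units; beyond the scatter) toward stronger inhibition. The estimate for compound 4 is 110 nM, with a range of 40 nM to 350 nM.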

Compound 4, half-maximal inhibitory concentration: 60 nM
Compound 4: the middle estimate sits 1.8-fold (0.26 log units) above what was measured; the range from low to high includes it.
By their numbers in this assay, from the lowest: compounds 1 and 4 (each within the scatter of the next); then compound 2; then compound 3.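

Cyclopentyl in place of 1-benzyl-1H-1,2,3-triazol-4-yl on the saturated chain carbon bound to an aromatic nitrogen gives a large step in this assay (a 15-fold lower number from compound 2 to compound 4 (1.18 log units; beyond the scatter)), larger than the step seen at the amine nitrogen in the ring (a 4.4-fold higher number from compound 2 to compound 3 (0.65 log units; beyond the scatter)). With cyclopentyl in place, methyl in place of hydrogen on that nitrogen stays within the scatter (a 1.2-fold higher number from compound 1 to compound 4 (0.08 log units; within the scatter)). Nothing available explains the size of either step. Still open, from the compounds shown here alone, is how a phenyl group at the same place would read, and whether an acetyl group on the amine nitrogen would move the number with cyclopentyl present.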